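The source may hold more compounds than are shown below. What is called first, only, known or untested is meant among the compounds shown, and "the series" means these compounds.

Three compounds have so far been measured in a functional assay on OVCAR-3 cells (Homo sapiens) for cytotoxicity, read by sulforhodamine B assay, with a stated time of 48 h; a higher number here means that more compound is tolerated, a lower number that less compound is tolerated:

compound 1 `ClCc1ccccc1Cn1cnc2c(Cl)ncnc21`: 8910 nM
compound 2 `ClCc1cccc(Cn2cnc3ncnc(Cl)c32)c1`: 43700 nM
compound 3 `ClCc1ccccc1Cn1cnc2ncnc(Cl)c21`: 8310 nM

Compound 3 gives the lowest of these three numbers. Compound 1 sits within the usual scatter of compound 3, so the two cannot be told apart, whereas compound 2 gives a number well beyond the scatter above compound 3.

Compound 4 `ClCc1ccccc1Cn1cnc2nc(Cl)nc(Cl)c21` differs from compound 3 in one place: chloro in place of hydrogen on an aromatic carbon. Among the measured compounds shown here, no measured pair shows the effect of this change, so the direction is open. A small step is expected, if anything toward a lower number in this assay, and it may well fall within the scatter. Compound 4 is therefore estimated at 6000 nM, with a range from 2000 nM to 20000 nM. This expected change corresponds to a 1.4-fold lower number from compound 3 to compound 4 (0.14 log units; within the scatter).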

Compound 4, concentration lethal to 50% of the cells: 53700 nM
For compound 4 the middle estimate is 9.0-fold (0.95 log units) below the measured one; the measured number lies above the stated range.
By their numbers in this assay, from the lowest: compounds 3 and 1 (each within the scatter of the next); then compounds 2 and 4 (each within the scatter of the next).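

In this assay, chloro in place of hydrogen on the aromatic carbon between two ring nitrogen atoms gives a 6.5-fold higher number from compound 3 to compound 4 (0.81 log units; beyond the scatter), so more compound is tolerated. Among the compounds shown here, this is the first sign that a change at this position can shift the number beyond the usual scatter. Nothing measured here accounts for the size or direction of this step. From the compounds shown here alone, it remains open whether an amine or a methoxy group on this carbon would shift the number in the same direction, and whether chloro here would have a similar effect on compound 1 or compound 2.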